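Will compound 3 keep the stability of compound 2?

The compounds below may be only part of what the source reports. "The series", "measured", "known", "first", "only" and "open" are said of these compounds alone.

Measured in an ADME assay (liver) for metabolic stability, with Liver microsome (Rattus norvegicus) as the target, read by LC-MS, using microsomes and NADPH, with stated times of 5 min and 60 min, tested at 4 uM; on this read-out higher numbers stand for a more stable compound and lower numbers for a less stable compound:
compound 1 `COc1ccc(C(=O)O)cc1OCCCCOc1ccc(C(=O)CC2CCCC2)c(O)c1C`: 14%
compound 2 `Cc1c(OCCCCOc2ccc(C(=O)O)c(Cl)c2)ccc(C(=O)CC2CCCC2)c1O`: 67%

Compound 2 holds the higher of these two numbers. Compound 3 `Cc1cc(C(=O)O)ccc1OCCCCOc1ccc(C(=O)CC2CCCC2)c(O)c1C`, not yet measured, differs from it at one place: 4-carboxy-2-methylphenyl in place of 4-carboxy-3-chlorophenyl on an oxygen on a saturated carbon. Among the measured compounds shown here, only one measured step bears on that place, and it is large: a number 53 percentage points higher from compound 1 to compound 2 (beyond the scatter). The group now leaving is the one that arrived with that step, while the entering group has no measurement of its own. A partial loss of that gain in this assay is therefore expected, an estimated a number 22 percentage points lower from compound 2 to compound 3 (beyond the scatter). For compound 3 the expected value is 45%, with a range of 20% to 72%.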

Compound 3, percent of the compound remaining: 59%
Beside the measured number, compound 3's estimate is 14 percentage points below it; measured number inside the range.
By their numbers in this assay, from the lowest: compound 1; then compounds 3 and 2 (each within the scatter of the next).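

In this assay, putting 4-carboxy-2-methylphenyl in place of 4-carboxy-3-chlorophenyl gives a number 8 percentage points lower from compound 2 to compound 3 (within the scatter), so these two groups cannot be told apart here. The rise over the 5-carboxy-2-methoxyphenyl group does not depend on the chlorine, as the methyl-bearing group also gives a number 45 percentage points higher from compound 1 to compound 3 (beyond the scatter). No measurement shown explains this difference. Still open, from the compounds shown here alone, is whether the methoxy group or the position of the carboxylic acid accounts for the low number of compound 1. Also open, going by these compounds, is how a tetrazole in place of that carboxylic acid would fare in this assay.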